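A few compounds are considered here, and "the series" means these few. Any claim that something is new, unique, unknown or untested is made for them only; others in the source may bear on it.

Of the compounds shown here, three built on one shared core have been tested in a functional assay on A549 cells (Homo sapiens) for antiproliferative activity, with a stated time of 5 days; a lower number here means a stronger inhibitor, a higher number a weaker inhibitor. Compound 1, `O=C1C=CC2(C=C1)OCC(=O)N2c1nc(-c2ccc3ccccc3c2Br)nn1-c1ccccc1`, gives 100 nM in this assay. Compound 2, `O=C1C=CC2(C=C1)OCC(=O)N2c1nc(-c2ccc3ccccc3c2)nn1-c1ccc(Cl)cc1`, gives 400 nM in this assay, and compound 3, `Cc1ccc(-n2nc(-c3ccc4ccccc4c3)nc2N2C(=O)C(C)OC23C=CC(=O)C=C3)cc1`, gives 1210 nM in this assay. Compound 1 thus shows the lowest number of the three, and its gaps to compound 2 and to compound 3 both lie beyond the usual scatter, so compound 1 is the strongest inhibitor of this set.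

Compound 4, `O=C1C=CC2(C=C1)OCC(=O)N2c1nc(-c2ccc(F)c3ccccc23)nn1-c1ccccc1`, has not yet been measured. It differs from compound 1 in one place: 4-fluoronaphthalen-1-yl in place of 1-bromonaphthalen-2-yl on an aromatic carbon. A 1-bromonaphthalen-2-yl group leaves and a 4-fluoronaphthalen-1-yl group enters, on an aromatic carbon between two ring nitrogen atoms of the shared core. Going by the values given here, no measured pair shows this same change, so there is no direct precedent for its size. Starting from compound 1 at 100 nM, compound 4 is expected to come out somewhat weaker, with a step of a 3.0-fold higher number from compound 1 to compound 4 (0.48 log units; beyond the scatter) that may just pass the scatter. The estimate for compound 4 in this assay is 300 nM, within a range from 100 nM to 900 nM.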

Compound 4, half-maximal inhibitory concentration: 320 nM
Compound 4: middle estimate off by 1.1-fold (0.03 log units), on the low side; the range from low to high includes it.
By their numbers in this assay, from the lowest: compound 1; then compounds 4 and 2 (each within the scatter of the next); then compound 3.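

In this assay, placing 4-fluoronaphthalen-1-yl instead of 1-bromonaphthalen-2-yl on the aromatic carbon between two ring nitrogen atoms gives a 3.2-fold higher number from compound 1 to compound 4 (0.51 log units; beyond the scatter), a modest step beyond the scatter. Going by these compounds alone, this is the first one-place comparison in the set, and it shows that the number at this position shifts even though both groups have the same count of heavy atoms and two carbon-only aromatic rings. Nothing available explains why this step occurs.

The change swaps bromine for fluorine and also moves the naphthalene's point of attachment, and the compounds shown cannot separate these two differences. Going by these compounds, a 1-fluoronaphthalen-2-yl group would isolate the halogen, while a 4-bromonaphthalen-1-yl group would isolate the attachment point, and an aminonaphthalene at this carbon also remains open.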